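Fluoro to methoxy on the distal ring of compound 1

The source may report more compounds than this note shows. Statements on the series, on what has been measured and on what is new or still open speak of the compounds shown alone.

Measured compounds:
compound 1, `O=C(NCCCCc1ccccc1)n1c(=O)oc2cc(-c3ccc(F)cc3)ccc21`: 79 nM
compound 2, `Cc1cccc2oc(=O)n(C(=O)NCCCCc3ccccc3)c12`: no result reported

For the measured compounds named here, compound 1 is the only compound of this set with a number in an assay on HEK293 cells for inhibition of acid ceramidase (Homo sapiens), with a stated time of 10 min (on this read-out higher numbers stand for weaker inhibition and lower numbers for stronger inhibition), where compound 1 gives 79 nM. Compound 2 was run in the same assay but no single number came out of it, so it gives no point of comparison.

Compound 3, `COc1ccc(-c2ccc3c(c2)oc(=O)n3C(=O)NCCCCc2ccccc2)cc1`, differs from compound 1 in one place: methoxy in place of fluoro on an aromatic carbon. The change sits on an aromatic carbon of a six-membered aromatic ring of carbon only, para to a large group, so the shared core of compound 1 and its four-carbon chain to the phenyl are untouched.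

Going by the values given here, no step between two measured compounds is available to calibrate such a swap, so the size and direction of the move from compound 1 to compound 3 rests on the change alone. A shift in this assay that does not exceed the usual scatter is expected, with no clear direction; the expected step is a 1.1-fold lower number from compound 1 to compound 3 (0.02 log units; within the scatter). Compound 3 is therefore estimated at 75 nM, in the range from 25 nM to 220 nM.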

Compound 3, half-maximal inhibitory concentration: 67 nM
Estimate against measurement, compound 3: 1.1-fold (0.05 log units) above; low and high end bracket the measured number.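

In this assay, for the compounds shown here, the change from 4-fluorophenyl to 4-methoxyphenyl gives a 1.2-fold lower number from compound 1 to compound 3 (0.07 log units; within the scatter), the first step in this set that can be read at all. On an aromatic carbon para to a large group, then, methoxy can stand in for fluoro with no shift beyond the usual scatter, even though methoxy counts a hydrogen-bond acceptor where fluoro counts none. The shared core and the four-carbon chain to the phenyl stay the same across this pair, so the comparison speaks only to this one place, and no measurement available here bears on the reason for the result.

On these data alone, two groups at one place give a single step, so it remains open whether this tolerance extends to quite different groups there, such as an amine, a carboxylic acid or a longer alkoxy chain like butoxy. As far as these compounds go, it is equally open whether methoxy in place of fluoro would behave the same way on another aromatic carbon or on a different core, since compound 2 offers no number to compare.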